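A few compounds are considered here, and "the series" means these few. Any claim that something is new, unique, unknown or untested is made for them only; others in the source may bear on it.

Compound 1 `COc1ccccc1-c1ccc2ncn(-c3cc(OC)c(OC)c(OC)c3)c2c1` is one of three close analogues that share a core and differ only in the aryl group attached on an aromatic carbon of that core. In a functional assay on SGC-7901 cells (Homo sapiens) for antiproliferative activity, read by MTT assay, with a stated time of 72 h (on this read-out lower numbers stand for stronger inhibition and higher numbers for weaker inhibition), compound 1 gives 5050 nM, the second highest of the three numbers. Compound 2 `COc1cc(-n2cnc3ccc(-c4cc(F)ccc4F)cc32)cc(OC)c1OC` gives 6590 nM in this assay, and the difference between the two is a 1.3-fold higher number from compound 1 to compound 2 (0.12 log units; within the scatter). Compound 3 `COc1cc(-n2cnc3ccc(-c4ccccc4)cc32)cc(OC)c1OC`, carrying an unsubstituted phenyl, gives 290 nM; the change of a 17-fold lower number from compound 1 to compound 3 (1.24 log units; beyond the scatter) and a 23-fold lower number from compound 2 to compound 3 (1.36 log units; beyond the scatter) both show that removing the substituents from that phenyl ring makes a large difference.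

Compound 4 `COc1cc(-n2cnc3ccc(-c4ccc(O)cc4)cc32)cc(OC)c1OC` is not yet measured in this assay. It differs from compound 1 as follows: 4-hydroxyphenyl in place of 2-methoxyphenyl on an aromatic carbon. For the measured compounds named here, the step from compound 1 to compound 3 bears on this, since it also removes the 2-methoxy group, but no measured compound tells what a hydroxy group on the phenyl does. The number for compound 4 is therefore estimated to fall between those of compound 1 and compound 3, giving an expected step of a 3.4-fold lower number from compound 1 to compound 4 (0.53 log units; beyond the scatter). Compound 4 is expected to give about 1500 nM, with a range from 300 nM to 8000 nM.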

Compound 4, half-maximal inhibitory concentration: > 10000 nM
Compound 4: no number, only a limit (the forecaster's own chance of this, stated with the estimate: 5%); middle value at least 6.6-fold (0.82 log units) away from the limit.
By their numbers in this assay, from the lowest: compound 3; then compounds 1 and 2 (each within the scatter of the next). At a limit, above all of these: compound 4.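

In this assay the reading for compound 4 is a limit of the assay and not a number: the limit of > 10000 nM in this assay, at which 1 of the 4 values shown sits. Hydroxy in place of hydrogen on the phenyl gives an at least 34-fold higher number from compound 3 to compound 4 (1.53 log units; beyond the scatter), so a single hydroxy group is enough to lose most of what compound 3 shows, and each of the three substituted phenyl compounds now stands beyond the scatter from compound 3. Against the other two substituted compounds the limit allows no ranking, with an at least 1.9-fold higher number from compound 1 to compound 4 (0.29 log units; that floor lies within the scatter) and an at least 1.5-fold higher number from compound 2 to compound 4 (0.18 log units; that floor lies within the scatter).

The compounds shown leave open whether this loss follows the hydroxy group itself or any group at that place on the phenyl. Going by these compounds, what a methoxy group or an amine would give in place of that hydroxy remains unknown.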